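The compounds below may be only part of what the source reports. "The series", "measured", "known", "first", "only" and "open" are said of these compounds alone.

Within the data shown here, in a functional assay on the whole organism with Mus musculus as the target, at a dose of 200 mg/kg by the intravenous route (on this read-out higher numbers stand for an effect only at larger amounts of compound and lower numbers for an effect already at smaller amounts), only two compounds have numbers so far. Compound 2 (`C[C@H](NCc1ccc(OCc2ccccc2)cc1)C(N)=O`) holds the lower of them at 16.9 mg/kg and so shows its effect already at smaller amounts. Compound 1 (`CN(C)C(=O)CNCc1ccc(OCc2cccc(Cl)c2)cc1`) gives 54.2 mg/kg in the same test, and this gap between the two lies beyond the usual scatter. The two differ in more than one place, so their values alone say little about any single change.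

Attention now turns to compound 3 (`CNC(=O)[C@@H](CO)NCc1ccc(OCc2ccccc2)cc1`), which has not yet been measured. Its structural change from compound 2 is 2-hydroxy-1-(methylcarbamoyl)ethyl in place of 1-carbamoylethyl on an amine nitrogen and the rest of the molecule stays the same. In words, 2-hydroxy-1-(methylcarbamoyl)ethyl takes the place of 1-carbamoylethyl on an amine nitrogen.

Among the measured compounds shown here, no measured pair shows what such a swap does, so any forecast remains loose. In this assay the expected step is a 1.8-fold higher number from compound 2 to compound 3 (0.25 log units; within the scatter) as a modest move toward a higher number, and it is expected to stay roughly within the scatter. For compound 3 the estimated value is 30 mg/kg with an expected range from 12 mg/kg to 80 mg/kg on this read-out.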

Compound 3, dose for half-maximal effect: 16.3 mg/kg
Compound 3: the middle estimate sits 1.8-fold (0.26 log units) above what was measured, and the stated range covers the measured number.
By their numbers in this assay, from the lowest: compounds 3 and 2 (each within the scatter of the next); then compound 1.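

In this assay, among these compounds, placing 2-hydroxy-1-(methylcarbamoyl)ethyl where 1-carbamoylethyl stood on an amine nitrogen gives a 1.0-fold lower number from compound 2 to compound 3 (0.02 log units; within the scatter), the first step that can be read at a single place. The entering group has more heavy atoms, hydrogen-bond donors and hydrogen-bond acceptors than the group it replaces, yet the two numbers remain within the scatter of each other, so at this position and on this read-out the larger group is tolerated. Nothing available bears on why the two groups read alike.

Among the compounds shown here, the single step does not separate the hydroxy part of the entering group from the methyl on its amide, so neither can be judged alone, and compound 1 differs from both compound 2 and compound 3 in more than one place, so its number cannot be tied to this position. From the compounds shown here alone, it also remains open how a carboxylic acid in place of the amide, or a longer carbon chain on the same amine nitrogen, would read in this assay.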